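Amide side-chain ring variation on the shared core

A few compounds are considered here, and "the series" means these few. Any claim that something is new, unique, unknown or untested is made for them only; others in the source may bear on it.

Compound 1 `COc1ccc(C2=NN(C(=O)CN3CCCCC3)C(c3cc(Cl)ccc3O)C2)cc1` gives 9650 nM in an assay on isolated protein for inhibition of Amine oxidase [flavin-containing] A (Homo sapiens), read by fluorescence, with stated times of 15 min and 20 min; on this read-out higher numbers stand for weaker inhibition and lower numbers for stronger inhibition. Compound 2 `CC1=NN(C(=O)CN2CCCCC2)C(c2cc(Br)cc(Br)c2O)C1` gives 7800 nM in this assay, and compound 3 `CC1=NN(C(=O)CN2CCNCC2)C(c2cc(Br)cc(Br)c2O)C1` gives 2000 nM in this assay, the lowest of the three numbers, with compound 2 nearest and compound 1 furthest. Within the data shown here, the only single-place step among the measured compounds is a 3.9-fold lower number from compound 2 to compound 3 (0.59 log units; beyond the scatter). Compound 4 `CC1=NN(C(=O)CN2CCC(O)CC2)C(c2cc(Br)cc(Br)c2O)C1` differs from compound 3 by 4-hydroxypiperidin-1-yl in place of piperazin-1-yl on a saturated chain carbon bound to a carbonyl carbon. The step from compound 2 to compound 3 bears on this change because a 3.9-fold lower number from compound 2 to compound 3 (0.59 log units; beyond the scatter) shows that the ring on this chain carbon matters; compound 4 retains a donor, so a step back toward compound 2 of at most modest size is expected. That expectation means a 1.8-fold higher number from compound 3 to compound 4 (0.24 log units; within the scatter). Compound 4 is therefore estimated at 3500 nM, within 1500 nM to 8000 nM.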

Compound 4, half-maximal inhibitory concentration: 12400 nM
The estimate for compound 4 lay 3.5-fold (0.55 log units) below the measured number; the measured number lies above the stated range.
By their numbers in this assay, from the lowest: compound 3; then compounds 2, 1 and 4 (each within the scatter of the next).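

The two rings count the same hydrogen-bond donors and acceptors, yet on this chain carbon the change gives a 6.2-fold higher number from compound 3 to compound 4 (0.79 log units; beyond the scatter) so those counts alone do not set the number at this position. Hydroxy in place of hydrogen on a saturated ring carbon gives a 1.6-fold higher number from compound 2 to compound 4 (0.20 log units; within the scatter) so among these three rings only piperazin-1-yl stands apart. Nothing measured here accounts for the difference between the rings.
Going by these compounds, whether a 4-aminopiperidin-1-yl or morpholin-4-yl ring on this chain carbon would group with compound 3 or with compound 4 remains open. Also open, on these data alone, is whether piperazin-1-yl has the same effect on the core of compound 1.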